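Replacing the Aniline Amine with a Larger Azo-Bearing Group

A few compounds are considered here, and "the series" means these few. Any claim that something is new, unique, unknown or untested is made for them only; others in the source may bear on it.

The series rests on two measured cores. Compound 1, `Cc1nc2cnccc2n1CC1CCN(C(=O)CC(C)(C)c2ccc(N)cc2)CC1`, gives 19 nM in a functional assay on the whole organism with Oryctolagus cuniculus as the target; on this read-out lower numbers stand for stronger inhibition and higher numbers for weaker inhibition. Compound 2, `CCOC(=O)[C@H](CC(C)C)N(Cc1ccc(N)cc1)S(=O)(=O)c1ccc(Cn2c(C)nc3cnccc32)cc1`, has a different core, and the difference between the two cores is not broken down here; in this assay compound 2 gives 12 nM, which lies within the usual scatter of the number for compound 1, so no order between the two is claimed.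

Compound 3, `Cc1nc2cnccc2n1CC1CCN(C(=O)CC(C)(C)c2ccc(/N=N\c3ccc(O)c(C(=O)O)c3)cc2)CC1`, differs from compound 1 by a group of 12 heavy atoms (7 carbon, 2 nitrogen, 3 oxygen; one six-membered aromatic ring of carbon only) in place of one nitrogen atom, on an aromatic carbon. This change brought an 84-fold higher number from compound 1 to compound 3 (1.93 log units; beyond the scatter), and in this assay compound 3 gives 1600 nM.

Compound 4, `CCOC(=O)[C@H](CC(C)C)N(Cc1ccc(/N=N\c2ccc(O)c(C(=O)O)c2)cc1)S(=O)(=O)c1ccc(Cn2c(C)nc3cnccc32)cc1`, is not yet measured. Within the data shown here, it differs from compound 2 by a group of 12 heavy atoms (7 carbon, 2 nitrogen, 3 oxygen; one six-membered aromatic ring of carbon only) in place of one nitrogen atom, on an aromatic carbon, and this is the same change as the one from compound 1 to compound 3, at the same kind of place on the core. Among the compounds shown this change occurs twice, once measured and once pending.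

Among the measured compounds shown here, because the single measured instance gave an 84-fold higher number from compound 1 to compound 3 (1.93 log units; beyond the scatter), the expectation for compound 4 rests on that step alone, carried over onto the core of compound 2. The step from compound 2 to compound 4 in this assay is therefore estimated at an 83-fold higher number from compound 2 to compound 4 (1.92 log units; beyond the scatter), beside the earlier one. For the measured compounds named here, compound 4 is accordingly expected to give 1000 nM in this assay, with a plausible range from 300 nM to 3500 nM, since only one prior example supports the transfer and the two cores themselves differ in a way not counted here.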

Compound 4, half-maximal inhibitory concentration: 490 nM
Compound 4: the middle estimate sits 2.0-fold (0.31 log units) above what was measured, within the range that was stated.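

In this assay, putting the larger azo-bearing group in place of the amino group on the core of compound 2 brought a 41-fold higher number from compound 2 to compound 4 (1.61 log units; beyond the scatter), a large step in the same direction as the one seen on the core of compound 1. The two steps do not differ beyond the scatter, so in this series the change carried across from one core to the other, with the direction kept and the size matching as closely as such measurements can tell: the same change on two cores in this assay, an 84-fold higher number (1.93 log units; beyond the scatter) from compound 1 to compound 3 and a 41-fold higher number (1.61 log units; beyond the scatter) from compound 2 to compound 4, 2.1-fold (0.31 log units) apart, within the scatter of two such steps. This agreement rests on two cores and on one replacement only; it does not show that the step would hold on any further core, and it does not explain why the number rises, nor does it make the two cores comparable with each other.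

The compounds shown compare only the amino group with the whole entering group, so they leave open which part of that group accounts for the step, for instance whether a plain phenylazo group without the hydroxyl and the carboxylic acid would give a step of like size. On these data alone, it also remains open whether a smaller replacement for the amino group, such as an acetamide, would raise the number on either core.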